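Swapping benzyloxy for methoxymethyl

The source may hold more compounds than are shown below. What is called first, only, known or untested is meant among the compounds shown, and "the series" means these compounds.

In a functional assay on the whole organism with Rattus norvegicus as the target (a lower number here means that less compound is needed, a higher number that more compound is needed for the effect), compound 2 `CCOCCOC(=O)C(=O)Nc1nc(-c2cc(OCc3ccccc3)no2)cs1` reads > 100 mg/kg, which is a limit of the assay and not a number. Its relative compound 1 `CCOCCOC(=O)C(=O)Nc1nc(-c2cc(OC)no2)cs1` gives 11 mg/kg. Among the compounds with values here, the only measured step, an at least 9.0-fold higher number from compound 1 to compound 2 (0.95 log units; beyond the scatter), lies beyond the scatter and came with phenyl in place of hydrogen on a saturated chain carbon. Compound 3 `CCOCCOC(=O)C(=O)Nc1nc(-c2cc(COC)no2)cs1` carries methoxymethyl in place of benzyloxy on an aromatic carbon, so that phenyl is gone again. A drop back towards compound 1 is therefore expected in this assay, and the expected step is an at least 5.0-fold lower number from compound 2 to compound 3 (0.69 log units; beyond the scatter). For compound 3 the estimate is 20 mg/kg, with an expected range of 6 mg/kg to 70 mg/kg.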

Compound 3, dose for half-maximal effect: 0.7 mg/kg
The estimate for compound 3 lay 29-fold (1.46 log units) above the measured number, outside the stated range (below it).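

At this aromatic carbon, small changes in the group matter more than the earlier pair could show: in this assay, methoxymethyl in place of benzyloxy gives an at least 140-fold lower number from compound 2 to compound 3 (2.15 log units; beyond the scatter), and methoxymethyl in place of methoxy gives a 16-fold lower number from compound 1 to compound 3 (1.20 log units; beyond the scatter). Neither methoxy nor methoxymethyl carries a phenyl, so losing the phenyl does not explain all of the gain, since compound 3 also moves well past compound 1. The first step has no upper end, since compound 2 stands at a limit of the assay and not at a number: the limit of > 100 mg/kg in this assay, at which 1 of the 3 values shown sits.

From the compounds shown here alone, what a longer chain such as ethoxymethyl or an amine such as aminomethyl would give at this carbon stays open.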